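The compounds below may be only part of what the source reports. "The series", "measured", "known", "first", "only" and "open" are said of these compounds alone.

Of the compounds shown here, two of a shared core have been measured in a functional assay on HCT-116 cells (Homo sapiens) for antiproliferative activity, read by MTT assay, with a stated time of 24 h; on this read-out lower numbers stand for stronger inhibition and higher numbers for weaker inhibition. Compound 1 `COc1ccc(C(=O)/C=C/c2ccccn2)c2c1C=CC(C)(C)O2` gives 6630 nM in this assay. Compound 2 `COc1ccc(C(=O)/C=C/c2ccc(Cl)cc2)c2c1C=CC(C)(C)O2` carries a 4-chlorophenyl in place of the pyridin-2-yl of compound 1. In this assay compound 2 reaches only the limit and is recorded as > 10000 nM, a limit rather than a number. Among the compounds with values here, the only step measured so far, an at least 1.5-fold higher number from compound 1 to compound 2 (0.17 log units; that floor lies within the scatter), is therefore a floor set by the limit of > 10000 nM in this assay, at which 1 of the 2 values shown sits, and it says only that compound 2 is at the weak end of what was measured.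

Compound 3 `COc1ccc(C(=O)/C=C/c2ccc(O)c(Br)c2)c2c1C=CC(C)(C)O2` differs from compound 2 in one place: 3-bromo-4-hydroxyphenyl in place of 4-chlorophenyl on a double-bonded chain carbon bound to a double-bonded chain carbon. Within the data shown here, no measured step covers an exchange of this kind, so the expectation for compound 3 rests on the fact that compound 2 sits at the limit and on the size of the change. Compound 3 is expected to land around 9000 nM in this assay, within 3000 nM to 30000 nM, and the expected step of an at least 1.1-fold lower number from compound 2 to compound 3 (0.04 log units; that floor lies within the scatter) is not one that can be told apart from the scatter with confidence.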

Compound 3, half-maximal inhibitory concentration: > 10000 nM
Compound 3: no number, only a limit; the forecaster's own chance of this, stated with the estimate: 50%; middle value at least 1.1-fold (0.04 log units) away from the limit.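

In this assay compound 3 is recorded at > 10000 nM, which is a limit and not a number. Within the data shown here, exchanging 4-chlorophenyl for 3-bromo-4-hydroxyphenyl on a double-bonded chain carbon bound to a double-bonded chain carbon adds a hydrogen-bond donor and a hydrogen-bond acceptor, yet it yields no number, and the step between compound 2 and compound 3 cannot be read because both stand at the same limit: the limit of > 10000 nM in this assay, at which 2 of the 3 values shown sit. The one step that can be read, an at least 1.5-fold higher number from compound 1 to compound 3 (0.17 log units; that floor lies within the scatter), is only a floor, so pyridin-2-yl remains the only group at this place with a number.

Going by these compounds, how far the two substituted phenyl groups lie beyond the limit stays open, and so does whether any group at this place can give a number clearly lower than that of pyridin-2-yl. On these data alone, whether a pyridin-3-yl, or a phenyl carrying an amine or a carboxylic acid, would give a readable number in this assay also remains open.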